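The compounds below may be only part of what the source reports. "The series", "measured", "known", "first", "only" and "open" are said of these compounds alone.

Series notes, agonist activity in an in vitro functional assay on cells for agonist activity at Bombesin receptor subtype-3 (Homo sapiens), read by luminescence and calcium flux; a higher number here means that more compound is needed for the effect, a lower number that less compound is needed.

Measured so far:
- compound 1 `O=C(O)c1ccccc1-c1ccc(CCc2ncc(Cc3ccccc3F)[nH]2)cc1`: 177 nM
- compound 2 `O=C(O)c1ccccc1-c1ccc(CCc2ncc(Cc3cccc(Cl)c3)[nH]2)cc1`: 825 nM
- compound 3 `CC(C)(C)Cc1cnc(CCc2ccc(-c3ccccc3C(=O)O)cc2)[nH]1`: 106 nM

Compound 3 gives the lowest number of the three. Its nearest neighbour is compound 1, with a 1.7-fold lower number from compound 1 to compound 3 (0.22 log units; within the scatter), a difference that stays within the scatter; the step from compound 2 is larger, a 7.8-fold lower number from compound 2 to compound 3 (0.89 log units; beyond the scatter), and lies beyond it. Between the two aryl analogues there is a 4.7-fold higher number from compound 1 to compound 2 (0.67 log units; beyond the scatter).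

The next compound, compound 4 `O=C(O)c1ccccc1-c1ccc(CCc2ncc(Cc3ccccc3)[nH]2)cc1`, is not yet measured. Against compound 3 the change is phenyl in place of tert-butyl on a saturated chain carbon bound to an aromatic carbon. For the measured compounds named here, the steps that bear on it are those in which the same tert-butyl is swapped for a substituted phenyl: the exchange against 2-fluorophenyl cost little, a 1.7-fold lower number from compound 1 to compound 3 (0.22 log units; within the scatter), whereas the exchange against 3-chlorophenyl cost more, a 7.8-fold lower number from compound 2 to compound 3 (0.89 log units; beyond the scatter). An unsubstituted phenyl carries neither substituent, so the step in this assay is expected to be small to modest, toward a higher number, most likely closer to what compound 1 shows than to what compound 2 shows.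

For compound 4 the expected step is therefore a 1.9-fold higher number from compound 3 to compound 4 (0.28 log units; within the scatter). Compound 4 is estimated at 200 nM, with a range from 80 nM to 500 nM.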

Compound 4, half-maximal effective concentration: 205 nM
Beside the measured number, compound 4's estimate is 1.0-fold (0.01 log units) below it, within the range that was stated.
By their numbers in this assay, from the lowest: compounds 3, 1 and 4 (each within the scatter of the next); then compound 2.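

In this assay, phenyl in place of tert-butyl on a saturated chain carbon bound to an aromatic carbon gives a 1.9-fold higher number from compound 3 to compound 4 (0.29 log units; within the scatter) and so, within this small set, does not separate an aromatic ring from the branched alkyl group. The unsubstituted phenyl also gives the two halogen-bearing rings a common reference: hydrogen in place of fluoro gives a 1.2-fold higher number from compound 1 to compound 4 (0.06 log units; within the scatter) and leaves the number within the scatter, whereas hydrogen in place of chloro gives a 4.0-fold lower number from compound 2 to compound 4 (0.60 log units; beyond the scatter) and lies beyond it. Among the four compounds, the higher number therefore goes with the 3-chlorophenyl group of compound 2 rather than with the presence of a ring, since compound 1, compound 3 and compound 4 all lie within the scatter of the next in order.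

Going by these compounds, compound 1 and compound 2 differ in both the halogen and its place, so 2-chlorophenyl and 3-fluorophenyl would be needed to separate the two, while a longer chain such as phenethyl or a ring bearing an amine remains open. The compounds shown offer no measurement that accounts for the higher number of compound 2.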